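Trimethoxyphenyl series: moving the chlorines on the saturated carbon

The source may hold more compounds than are shown below. What is called first, only, known or untested is meant among the compounds shown, and "the series" means these compounds.

Measured so far:
compound 1 `COc1cc(C(=O)N/N=C/c2ccc(F)c(F)c2)cc(OC)c1OC`: 51.9%
compound 2 `COc1ccc(/C=N/NC(=O)c2cc(OC)c(OC)c(OC)c2)c(OC)c1`: 3.6%
compound 3 `COc1cc(C2=NN(C(C)=O)C(c3c(Cl)cccc3Cl)O2)cc(OC)c1OC`: 15.9%

All three were read in a functional assay on BGC-823 cells (Homo sapiens) for antiproliferative activity, read by MTT assay, tested at 5 uM; a lower number here means a weaker effect, a higher number a stronger effect of the compound at the concentration tested. Among the three numbers, compound 3 stands second highest with 15.9%. The nearest is compound 2, whose 3.6% lies lower by more than the scatter; the furthest is compound 1, whose 51.9% lies higher, again beyond the scatter. For the measured compounds named here, no two of the measured compounds differ in a single place, so no step within the measured set is known, and nothing in the data tells how a change on the dichlorophenyl group moves the read-out.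

Compound 4 `COc1cc(C2=NN(C(C)=O)C(c3cc(Cl)cc(Cl)c3)O2)cc(OC)c1OC` differs from compound 3 in one place only:
3,5-dichlorophenyl in place of 2,6-dichlorophenyl on a saturated ring carbon
The two compounds hold the same atoms, joined differently. Going by the values given here, with no comparable step in hand, the size of the step of a number 4.1 percentage points higher from compound 3 to compound 4 (within the scatter) is expected to be small, of the order of the scatter, with no firm direction. On that basis compound 4 is estimated at 20%, with a range from 5% to 40%.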

Compound 4, a percentage reported as inhibition, at one concentration (the size of the read-out at that concentration, not a potency): 6.6%
Compound 4: the middle estimate sits 13.4 percentage points above what was measured; measured number inside the range.
By their numbers in this assay, from the lowest: compounds 2, 4 and 3 (each within the scatter of the next, the first and the last beyond it); then compound 1.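

In this assay, for the compounds shown here, the exchange of 2,6-dichlorophenyl for 3,5-dichlorophenyl on the saturated ring carbon gives a number 9.3 percentage points lower from compound 3 to compound 4 (within the scatter) as the first step that can be read at a single place. At this position, rearranging the same two chlorines on the phenyl ring therefore does not separate the two compounds at the concentration tested. No available measurement speaks to the reason for this result.

As far as these compounds go, whether this position responds to a different kind of group on the phenyl ring, such as an amine or a carboxylic acid, remains open. Also open, from the compounds shown here alone, is whether a longer acyl chain in place of the acetyl group on the shared core would move the read-out beyond the scatter.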